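The source may hold more compounds than are shown below. What is called first, only, known or untested is meant among the compounds shown, and "the series" means these compounds.

Measured so far in an ADME assay on CHO cells (Cricetulus griseus) for cytotoxicity, read by LDH release; a lower number here means a stronger inhibitor, a higher number a weaker inhibitor:

compound 1 `CC(Oc1ccc(Cl)cc1Cl)C(=O)NCc1ccccc1F` gives 47000 nM
compound 2 `Cc1ccc(CNC(=O)C(C)Oc2ccc(Cl)cc2Cl)cc1` gives 25000 nM

Compound 2 and compound 1 lie within the scatter of each other, so neither stands clearly apart. Compound 3 `Cc1cccc(CNC(=O)C(C)Oc2ccc(Cl)cc2Cl)c1` has 3-methylphenyl in place of 4-methylphenyl on a saturated chain carbon bound to an amide-type nitrogen, with 3-methylphenyl in place of 4-methylphenyl on a saturated chain carbon bound to an amide-type nitrogen as the counted difference. Within the data shown here, the only measured guide, 4-methylphenyl in place of 2-fluorophenyl, is a 1.9-fold lower number from compound 1 to compound 2 (0.27 log units; within the scatter) and it suggests that no step beyond the scatter should be expected in this assay here. The expected step is a 1.2-fold higher number from compound 2 to compound 3 (0.08 log units; within the scatter) on this estimate. Compound 3 is estimated at 30000 nM (expected range 14000 nM to 60000 nM).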

Compound 3, half-maximal inhibitory concentration: 45000 nM
Beside the measured number, compound 3's estimate is 1.5-fold (0.18 log units) below it, within the range that was stated.
By their numbers in this assay, from the lowest: compounds 2, 3 and 1 (each within the scatter of the next).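

Moving the methyl group, from 4-methylphenyl to 3-methylphenyl on a saturated chain carbon bound to an amide-type nitrogen, gives a 1.8-fold higher number from compound 2 to compound 3 (0.26 log units; within the scatter) in this assay even though the two groups hold the same atoms. Placing 3-methylphenyl in place of 2-fluorophenyl gives a 1.0-fold lower number from compound 1 to compound 3 (0.02 log units; within the scatter) and so, at this position, compounds 1, 2 and 3 cannot be told apart. No supporting measurement is available to explain these numbers. Still open, as far as these compounds go, is whether an amine or a carboxylic acid on the aromatic ring would move the number beyond the scatter.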